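The source may report more compounds than this note shows. Statements on the series, on what has been measured and on what is new or still open speak of the compounds shown alone.

Measured compounds:
compound 1 `Cc1nc(-c2ccsc2)sc1COc1ccc2c(c1)OCC2CC(=O)O` — 68.5 nM
compound 2 `Cc1nc(-c2ccccc2Cl)sc1COc1ccc2c(c1)OCC2CC(=O)O` — "not determined" (no result reported)

Compound 1 `Cc1nc(-c2ccsc2)sc1COc1ccc2c(c1)OCC2CC(=O)O` was tested in a functional assay on CHO cells for agonist activity at Free fatty acid receptor 1 (Homo sapiens), read by FLIPR and calcium flux (on this read-out higher numbers stand for an effect only at larger amounts of compound and lower numbers for an effect already at smaller amounts), and gave 68.5 nM. Going by the values given here, compound 2 `Cc1nc(-c2ccccc2Cl)sc1COc1ccc2c(c1)OCC2CC(=O)O` shares the same core but carries a 2-chlorophenyl on the five-membered ring; in this assay compound 2 is entered as "not determined" (no result reported), so it stands nowhere on the scale and no step can be drawn from it to any other compound.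

Compound 3 `Cc1nc(-c2ccc(F)cc2)sc1COc1ccc2c(c1)OCC2CC(=O)O` differs from compound 2 in one place: 4-fluorophenyl in place of 2-chlorophenyl on an aromatic carbon. Among the compounds with values here, since compound 2 has no value, the size and direction of this step cannot be stated from the data; the only anchor is compound 1, whose thiophen-3-yl occupies the same position on the ring and which gives 68.5 nM. On that anchor alone, compound 3 is expected to land in the same region as compound 1, with no step beyond the scatter to be claimed in either direction. Compound 3 is therefore estimated at 80 nM, with a plausible range from 25 nM to 250 nM.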

Compound 3, half-maximal effective concentration: 48.7 nM
Compound 3: the middle estimate sits 1.6-fold (0.22 log units) above what was measured, within the range that was stated.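

In this assay, the aromatic carbon of the five-membered ring, next to the ring nitrogen and next to the ring sulfur, now carries a second group with a measured value, and a 1.4-fold lower number from compound 1 to compound 3 (0.15 log units; within the scatter) lies within the scatter. Going by these compounds alone, at this position, then, a six-membered aromatic ring of carbon only, as 4-fluorophenyl, cannot be told apart from the thiophen-3-yl of compound 1, which is the first sign that this place accepts more than one kind of aromatic ring without a step beyond the scatter. The step between compound 2 and compound 3 cannot be read, so 2-chlorophenyl adds nothing to this comparison, and no measurement at hand bears on the result.

The compounds shown leave open whether the fluorine on the phenyl ring matters at all, since a plain phenyl group does not stand among them, and whether a non-aromatic group such as a cyclohexyl ring or a piperidine with its ring amine would fit this position equally well. They also leave open what happens when the methyl group on the same ring gives way to an ethyl group or to a hydrogen.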